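This account rests on a few compounds, and the source may have more. Where it says the series, first, only, none or still open, it means among the compounds named here.

Compound 1 `Cc1cccc(/C(N)=N/NC(=S)N2CCCCC2)n1` is measured in a functional assay on A-375 cells (Homo sapiens) for cytotoxicity, read by MTT assay, with a stated time of 72 h (on this read-out higher numbers stand for weaker inhibition and lower numbers for stronger inhibition), where compound 1 gives 1000 nM. Among the three measured compounds this number stands second highest. Its nearest neighbour is compound 3 `N/C(=N\NC(=S)N1CCCCC1)c1ccccn1`, which in this assay gives 680 nM; the step of a 1.5-fold lower number from compound 1 to compound 3 (0.17 log units; within the scatter) rests on hydrogen in place of methyl on an aromatic carbon. Among the compounds with values here, compound 2 `N/C(=N\NC(=S)N1CCOCC1)c1ccc(F)cn1` gives 1500 nM, and compared with compound 1 this value lies within the scatter, although no single-point step joins the two.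

The unmeasured compound 4 `Cc1cccc(/C(N)=N/NC(=S)N2CCSCC2)n1` differs from compound 1 in one place: thiomorpholin-4-yl in place of piperidin-1-yl on a thiocarbonyl carbon. Within the data shown here, none of the measured steps touches the ring on the thiocarbonyl carbon, so no measured step bears directly on this change, and the only step at hand, from compound 1 to compound 3, is itself within the scatter. Compound 4 is therefore expected to stay close to compound 1, with the step of no change at the digits printed from compound 1 to compound 4 (within the scatter) expected to fall within the scatter. The estimate for compound 4 in this assay is 1000 nM, expected to lie between 400 nM and 2500 nM.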

Compound 4, half-maximal inhibitory concentration: 1400 nM
Compound 4: middle estimate off by 1.4-fold (0.15 log units), on the low side; low and high end bracket the measured number.
By their numbers in this assay, from the lowest: compounds 3, 1, 4 and 2 (each within the scatter of the next, the first and the last beyond it).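

The ring on the thiocarbonyl carbon had not been varied in any earlier step, and in this assay the exchange of piperidin-1-yl for thiomorpholin-4-yl gives a 1.4-fold higher number from compound 1 to compound 4 (0.15 log units; within the scatter). On the core of compound 1, this position therefore accepts a second hetero atom in the six-membered non-aromatic ring, and a hydrogen-bond acceptor that piperidin-1-yl lacks, without a change beyond the scatter. This rests on a single step on a single core, and no supporting data bear on why the number stays within the scatter.

Going by these compounds, it remains open whether this position would hold its number with an open-chain amine such as dimethylamino, a smaller pyrrolidin-1-yl ring or a piperazin-1-yl ring. On these data alone, it is also open whether thiomorpholin-4-yl would behave the same way on the core without the methyl group.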